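The source may report more compounds than this note shows. Statements on the series, on what has been measured and on what is new or still open speak of the compounds shown alone.

Measured compounds:
Compound 1, `Cn1ccnc1Sc1cnc(-c2ccc(N)cc2)nc1-c1ccccc1O`: in an ADME assay on MDCK cells (Canis lupus familiaris) for cytotoxicity (a lower number here means that less compound is tolerated, a higher number that more compound is tolerated), compound 1 gives 80100 ug/mL.
Compound 2, `COc1ccc(O)c(-c2ncncc2Sc2nccn2C)c1`: in this assay compound 2 gives 618000 ug/mL.

Compound 1 stands at the lower of the two numbers in this assay; compound 2 sits at a higher number, and the gap between them goes beyond the usual scatter of repeated measurements. Among the measured compounds shown here, compound 2 differs from compound 1 in more than one place, so no single structural change can be tied to that gap, and the two values show only that compound 2 is tolerated at the higher concentration.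

The unmeasured compound 3, `Cn1ccnc1Sc1cnc(-c2ccncc2)nc1-c1ccccc1O`, differs from compound 1 in just one place: pyridin-4-yl in place of 4-aminophenyl on an aromatic carbon. The rest of the shared core, with its 2-hydroxyphenyl group and its (1-methyl-1H-imidazol-2-yl)sulfanyl group, is unchanged. For the measured compounds named here, no measured pair isolates this exact exchange, so the size of the step in this assay has to be judged without a direct precedent. The expected step from compound 1 to compound 3 is a 1.2-fold higher number from compound 1 to compound 3 (0.10 log units; within the scatter), that is, a change no larger than the scatter, in either direction. For compound 3 the estimated value is 100000 ug/mL, with a range from 35000 ug/mL to 300000 ug/mL.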

Compound 3, half-maximal cytotoxic concentration: 64700 ug/mL
Beside the measured number, compound 3's estimate is 1.5-fold (0.19 log units) above it, and the stated range covers the measured number.
By their numbers in this assay, from the lowest: compounds 3 and 1 (each within the scatter of the next); then compound 2.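

Among the compounds shown here, the exchange of 4-aminophenyl for pyridin-4-yl, on the aromatic carbon between two ring nitrogen atoms, gives the first comparison in this assay that isolates a single change: a 1.2-fold lower number from compound 1 to compound 3 (0.09 log units; within the scatter). At this position, then, one six-membered aromatic ring can stand in for the other, and the hydrogen-bond donor counted on 4-aminophenyl can go, without the number moving beyond the scatter of repeated measurements. Nothing available explains why the two groups read alike in this assay.

For the compounds shown here, this single pair covers only two aromatic rings of similar size, so it remains open how the number would respond to a very different group at this position, such as a carboxylic acid, a morpholine or a longer alkyl chain. As far as these compounds go, it also remains open whether the same exchange would read alike if the 2-hydroxyphenyl group or the (1-methyl-1H-imidazol-2-yl)sulfanyl group on the shared core were replaced.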